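Isopropoxy in Place of Methylsulfanyl: What to Expect

The compounds below may be only part of what the source reports. "The series", "measured", "known", "first", "only" and "open" are said of these compounds alone.

Of the compounds shown here, two with a shared core have been measured. Compound 1 `O=c1c(-c2nn[nH]n2)c[nH]c2c(F)cccc12` carries fluoro on an aromatic carbon, and compound 2 `CSc1cccc2c(=O)c(-c3nn[nH]n3)c[nH]c12` carries methylsulfanyl at the same place. In a functional assay on the whole organism (strain Sprague-Dawley) for inhibition, with Rattus norvegicus as the target (a lower number here means that less compound is needed, a higher number that more compound is needed for the effect), compound 1 gives 10 mg/kg, while compound 2 gives 25 mg/kg, a step of a 2.5-fold higher number from compound 1 to compound 2 (0.40 log units; beyond the scatter). Among the compounds with values here, compound 2 thus stands with the higher of the two numbers known so far, with compound 1 as its only neighbour.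

Within the data shown here, compound 3 `CC(C)Oc1cccc2c(=O)c(-c3nn[nH]n3)c[nH]c12` is the next to be measured. isopropoxy in place of methylsulfanyl on an aromatic carbon Only one measured step exists, and it concerns fluoro against methylsulfanyl, not methylsulfanyl against isopropoxy, so it gives no direct guide for this change. With nothing bearing on it, the expectation for compound 3 is a step of about no change at the digits printed from compound 2 to compound 3 (within the scatter), none beyond the scatter. Compound 3 is therefore estimated at 25 mg/kg, within a range from 10 mg/kg to 60 mg/kg.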

Compound 3, minimum effective dose: 1.25 mg/kg
Estimate against measurement, compound 3: 20-fold (1.30 log units) above; the whole stated range lies above it.
By their numbers in this assay, from the lowest: compound 3; then compound 1; then compound 2.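

At this aromatic carbon, the group turns out to matter more in this assay than the first pair showed: the change to isopropoxy gives a 20-fold lower number from compound 2 to compound 3 (1.30 log units; beyond the scatter), and against fluoro it gives an 8.0-fold lower number from compound 1 to compound 3 (0.90 log units; beyond the scatter). The numbers do not simply follow the size of the group, since methylsulfanyl has more heavy atoms than fluoro and stands higher, while isopropoxy, with more heavy atoms still, stands lowest. No measurement at hand accounts for these steps.

The step from methylsulfanyl to isopropoxy exchanges sulfur for oxygen and alters the carbon count at once, so the compounds shown do not separate the two changes, and methoxy or isopropylsulfanyl would bear on this. As far as these compounds go, how an amine or a carboxylic acid at this carbon would compare also remains open.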